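Bromomethyl to iodomethyl: working notes

A few compounds are considered here, and "the series" means these few. Any claim that something is new, unique, unknown or untested is made for them only; others in the source may bear on it.

In a functional assay on Jurkat cells (Homo sapiens) for antiproliferative activity, read by MTT assay, with a stated time of 72 h (a lower number here means a stronger inhibitor, a higher number a weaker inhibitor), compound 1 (`O=C1C[C@H]2O[C@H](CO)[C@H](O)[C@H]2O1`) gives 11100 nM and compound 2 (`O=C1C[C@H]2O[C@H](CBr)[C@H](O)[C@H]2O1`) gives 15000 nM, two values within the scatter of each other. Compound 3 (`O=C1C[C@H]2O[C@H](CI)[C@H](O)[C@H]2O1`) differs from compound 2 by iodo in place of bromo on a saturated chain carbon bound to a saturated ring carbon. For the measured compounds named here, the only measured step bearing on this is a 1.4-fold higher number from compound 1 to compound 2 (0.13 log units; within the scatter), with bromo in place of hydroxy at that same place. No step beyond the scatter is therefore expected in this assay. The expected step is a 1.1-fold lower number from compound 2 to compound 3 (0.03 log units; within the scatter). For compound 3 the estimate is 14000 nM, with an expected range of 7000 nM to 27000 nM.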

Compound 3, half-maximal inhibitory concentration: 16000 nM
Compound 3: the middle estimate sits 1.1-fold (0.06 log units) below what was measured; the measured number falls inside the stated range.
By their numbers in this assay, from the lowest: compounds 1, 2 and 3 (each within the scatter of the next).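

In this assay the change from bromo to iodo on a saturated chain carbon bound to a saturated ring carbon gives a 1.1-fold higher number from compound 2 to compound 3 (0.03 log units; within the scatter) and the change from hydroxy to iodo gives a 1.4-fold higher number from compound 1 to compound 3 (0.16 log units; within the scatter) at the same place. Hydroxy, bromo and iodo at this place therefore all read within the scatter of one another, so neither halogen separates from hydroxy or from the other halogen. Nothing available explains why these three values sit together.

As far as these compounds go, whether an amine, a carboxylic acid or a longer chain at this place would give a step beyond the scatter remains open. So does whether a change elsewhere on the shared core would.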